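From Iodo to Chloro: One Atom Exchanged

The source may hold more compounds than are shown below. What is called first, only, known or untested is meant among the compounds shown, and "the series" means these compounds.

Compound 1 `Cc1cc(C(=O)/C=C/c2cc3cccc(C)c3nc2Cl)c(C)s1` and compound 2 `Cc1ccc2cc(/C=C/C(=O)c3ccc(I)s3)c(Cl)nc2c1` both belong to this small series, tested in a functional assay on HUVEC cells (Homo sapiens), read by BrdU incorporation, with a stated time of 72 h; on this read-out higher numbers stand for weaker inhibition and lower numbers for stronger inhibition. In this assay compound 1 has the entry "not determined" (no result reported). Going by the values given here, compound 2 gives 135 nM, the only number available, so it cannot yet be ranked against any other compound.

Compound 3 `Cc1ccc2cc(/C=C/C(=O)c3ccc(Cl)s3)c(Cl)nc2c1` keeps the core of compound 2 and differs in a single place: chloro in place of iodo on an aromatic carbon. The exchange lies next to the ring sulfur and turns 5-iodothiophen-2-yl into 5-chlorothiophen-2-yl.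

Among the compounds with values here, no measured pair shows what this exchange does in this assay. With so little to go on, the step of a 1.2-fold higher number from compound 2 to compound 3 (0.07 log units; within the scatter) is expected to stay within the usual scatter, with no firm direction. Compound 3 is estimated at 160 nM, with an expected range of 70 nM to 400 nM.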

Compound 3, half-maximal inhibitory concentration: 49.5 nM
The estimate for compound 3 lay 3.2-fold (0.51 log units) above the measured number; the whole stated range lies above it.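

Iodo to chloro on this aromatic carbon, next to the ring sulfur, is the first change in the series that can be read as a step, and in this assay it gives a 2.7-fold lower number from compound 2 to compound 3 (0.44 log units; beyond the scatter). The position is therefore not indifferent to which halogen it carries: exchanging one heavy atom for another, with no hydrogen-bond donor or acceptor entering or leaving, moves the number beyond the usual scatter, and compound 3 is the stronger inhibitor of this pair. No measurement shown here accounts for the step, so its cause remains unknown.

On these data alone, how a bromo, a methoxy or an amine at this place would read remains open. Also open, as far as these compounds go, is whether the same exchange would give a similar step on a different core.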